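This account rests on a few compounds, and the source may have more. Where it says the series, first, only, none or still open, it means among the compounds named here.

In a physicochemical assay for lipophilicity (on this read-out lower numbers stand for lower lipophilicity and higher numbers for higher lipophilicity), compound 3 (`Cc1cn(C2CC(N=[N+]=[N-])C(COC(=O)OCCCN)O2)c(=O)[nH]c1=O`) gives -0.93, within the scatter of compound 2 (`Cc1cn(C2CC(N=[N+]=[N-])C(COC(=O)NCCCC(=O)O)O2)c(=O)[nH]c1=O`) at -0.81 and clearly lower than compound 1 (`Cc1cn(C2CC(N=[N+]=[N-])C(COC(=O)OCCCCCCCCO)O2)c(=O)[nH]c1=O`) at 1.14. Compound 4 (`Cc1cn(C2CC(N=[N+]=[N-])C(COC(=O)CCCN)O2)c(=O)[nH]c1=O`) differs from compound 3 by 3-aminopropyl in place of 3-aminopropoxy on a carbonyl carbon. The closest measured change at such a carbon is a number 0.12 log units lower from compound 2 to compound 3 (within the scatter), within the scatter. The large steps of a number 1.95 log units lower from compound 1 to compound 2 (beyond the scatter) and a number 2.07 log units lower from compound 1 to compound 3 (beyond the scatter) both start from the long chain of compound 1, which compound 3 and compound 4 lack. Within the data shown here, no measured step isolates the present exchange. No step beyond the scatter is expected in this assay, and the estimated change is a number 0.13 log units higher from compound 3 to compound 4 (within the scatter). For compound 4 the estimate is -0.8, with an expected range from -1.3 to -0.3.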

Compound 4, partition coefficient: -0.9
Beside the measured number, compound 4's estimate is 0.10 log units above it, within the range that was stated.
By their numbers in this assay, from the lowest: compounds 3, 4 and 2 (each within the scatter of the next); then compound 1.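

In this assay, removing the oxygen of 3-aminopropoxy at this carbonyl carbon gives no step beyond the scatter: a number 0.03 log units higher from compound 3 to compound 4 (within the scatter). Exchange of (3-carboxypropyl)amino for 3-aminopropyl is also within the scatter, a number 0.09 log units lower from compound 2 to compound 4 (within the scatter), so all three short groups at this position read alike. Only the exchange from (8-hydroxyoctyl)oxy remains large: a number 2.04 log units lower from compound 1 to compound 4 (beyond the scatter). Nothing available explains these steps. Going by these compounds, whether an 8-aminooctyl group on this carbonyl carbon would read with compound 1 or with compound 4 remains open.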